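Bromo for Ethoxycarbonyl: From Compound 3 to Compound 4

This account rests on a few compounds, and the source may have more. Where it says the series, first, only, none or still open, it means among the compounds named here.

Of the compounds shown here, three have so far been measured in an ADME assay on the whole organism with Oryza sativa as the target, tested at 10 uM; on this read-out lower numbers stand for a stronger effect and higher numbers for a weaker effect at the one concentration tested. Compound 1 `Cc1ccc(NC(=O)N[C@@H](C)c2ccccc2)cc1` gives 100%. Compound 2 `CCOC(=O)c1cccc(NC(=O)N[C@H](C)c2ccccc2)c1` gives 88%, and compound 3 `CCOC(=O)c1cccc(NC(=O)N[C@@H](C)c2ccccc2)c1` gives 96%. Among the three numbers, that of compound 3 is the second highest, but its nearest neighbour, compound 1, and its furthest, compound 2, both lie within the scatter of it, so the three numbers cannot be told apart with confidence. Among the compounds with values here, the only pair that differs in one place gives a number 8 percentage points higher from compound 2 to compound 3 (within the scatter), a step that rests on the fact that compounds 2 and 3 differ only in the configuration as drawn and nothing more.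

The next compound, compound 4 `C[C@H](NC(=O)Nc1cccc(Br)c1)c1ccccc1`, differs from compound 3 by bromo in place of ethoxycarbonyl on an aromatic carbon. Within the data shown here, no measured step touches a substituent on this ring; the single step on record concerns configuration alone and stays within the scatter, so it offers no guide to the size or direction of this change. With all three measured numbers high and close together, compound 4 is expected to stay near them, and the step of a number 4 percentage points lower from compound 3 to compound 4 (within the scatter) is estimated to be small. Compound 4 is therefore estimated at 92%, with a range from 75% to 100%, pending the measurement.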

Compound 4, a percentage reported as activity, at one concentration (the size of the read-out at that concentration, not a potency): 99%
For compound 4 the middle estimate is 7 percentage points below the measured one; the measured number falls inside the stated range.
By their numbers in this assay, from the lowest: compounds 2, 3, 4 and 1 (each within the scatter of the next, the first and the last beyond it).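

Exchanging ethoxycarbonyl for bromo on an aromatic carbon, meta to a large group, gives a number 3 percentage points higher from compound 3 to compound 4 (within the scatter) in this assay. This is the first change shown at this position of the ring, and it is not a small one: the group that leaves has 5 heavy atoms and 2 hydrogen-bond acceptors, while bromo has 1 heavy atom and no hydrogen-bond acceptors, yet the read-out does not separate the two compounds. The pair therefore shows that, at the one concentration tested, this read-out does not tell these two substituents apart, and nothing on record offers a reason for that.

Still open, as far as these compounds go, is whether any other group at this position, such as an amine, a carboxylic acid or a longer chain, would move the number beyond the scatter. Also open, from the compounds shown here alone, is whether bromo would give the same picture with the opposite configuration at the stereocentre of the chain.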